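The source may report more compounds than this note shows. Statements on the series, on what has been measured and on what is new or still open speak of the compounds shown alone.

Measured compounds:
- Compound 1, `COc1cccc(Nc2ncc(C(=O)c3ccccc3F)s2)c1`: 1000 nM
- Compound 2, `CCc1ccccc1C(=O)c1cnc(Nc2cccc(C(F)(F)F)c2)s1`: 32 nM
- Compound 3, `O=C(c1cnc(Nc2cccc(C(F)(F)F)c2)s1)c1ccccc1C(F)(F)F`: 138 nM

These three compounds were tested in an assay for inhibition of Neuropeptide Y receptor type 5 (Mus musculus); a higher number here means a weaker inhibitor, a lower number a stronger inhibitor. Compound 3 sits second highest of the three numbers; its nearest neighbour is compound 2, and the gap to compound 1 is the wider one. The only step shown between two compounds differing in one place is a 4.3-fold higher number from compound 2 to compound 3 (0.63 log units; beyond the scatter), which concerns the ring carrying the carbonyl, not the ring carrying the amine.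

Compound 4, `N#Cc1cccc(Nc2ncc(C(=O)c3ccccc3C(F)(F)F)s2)c1`, differs from compound 3 in this way: cyano in place of trifluoromethyl on an aromatic carbon. This change sits on the amine-bearing ring, where no single-point step has been measured, so nothing shown bears on it directly. Compound 1 carries a methoxy group on that ring together with a fluoro on the other ring, and its value cannot be separated into two effects. Among the measured compounds shown here, with no direct precedent, the expected step of a 1.4-fold higher number from compound 3 to compound 4 (0.16 log units; within the scatter) is set small, near no change, but with a wide allowance either way. Compound 4 is therefore expected to give about 200 nM in this assay, estimated to lie between 60 nM and 700 nM.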

Compound 4, half-maximal inhibitory concentration: 20 nM
Compound 4: the middle estimate sits 10-fold (1.00 log units) above what was measured, outside the stated range (below it).
By their numbers in this assay, from the lowest: compounds 4 and 2 (each within the scatter of the next); then compound 3; then compound 1.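

In this assay, the position on the amine-bearing ring, meta to a large group, now has its first reading from a single change: with cyano in place of trifluoromethyl, the result is a 6.9-fold lower number from compound 3 to compound 4 (0.84 log units; beyond the scatter). Among the compounds shown here, until now, the only such step concerned the ring carrying the carbonyl, so this shows that the group on the other ring also matters, and that the step is beyond the usual scatter. The incoming cyano has two heavy atoms and one hydrogen-bond acceptor, while the outgoing trifluoromethyl has four heavy atoms and no acceptor, but nothing available here shows which of these differences, if either, accounts for the stronger inhibition.

What the compounds shown leave open is how this position would respond to other groups, such as an amine, a carboxylic acid or a single chlorine atom, which would show whether cyano is unusual there. Going by these compounds, it is also open whether the same swap would give a step of similar size with ethyl on the carbonyl-bearing ring, as in compound 2, rather than trifluoromethyl.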